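Nitro Addition and Cytotoxicity Toward Bovine Kidney Cells

The source may report more compounds than this note shows. Statements on the series, on what has been measured and on what is new or still open speak of the compounds shown alone.

Four compounds are compared in an ADME assay on MDBK cells (Bos taurus) for cytotoxicity, read by MTT assay, with a stated time of 96 h; on this read-out lower numbers stand for higher toxicity in this test and higher numbers for lower toxicity in this test. Compound 1, `CN(/N=N/c1ccccc1)c1ccccc1`, is the plainest of them. In this assay compound 1 gives > 100000 nM, which is a limit of the test and not a number. Compound 3, `CN(/N=N/c1cccc([N+](=O)[O-])c1)c1ccccc1`, carries a nitro group on one ring. In this assay compound 3 gives 82000 nM. The change from compound 1 to compound 3 is nitro in place of hydrogen on an aromatic carbon, and the resulting step is an at least 1.2-fold lower number from compound 1 to compound 3 (0.08 log units; that floor lies within the scatter); the floor of that step rests on (the limit of > 100000 nM in this assay, at which 1 of the 3 values shown sits).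

Compound 2, `CN(C)CCCNc1ccc(/N=N/c2ccccc2)cc1`, has a different core; how its core differs from that of compound 1 is not broken down here. In this assay compound 2 gives 58000 nM, which sits within the usual scatter of the value of compound 3.

Compound 4, `CN(C)CCCNc1ccc(/N=N/c2ccc([N+](=O)[O-])cc2)cc1`, has not yet been measured. It differs from compound 2 by nitro in place of hydrogen on an aromatic carbon. This is the same kind of change as that from compound 1 to compound 3, though the place differs: in compound 3 the nitro group sits meta to a large group, while in compound 4 it sits para to a large group.

Because the step of an at least 1.2-fold lower number from compound 1 to compound 3 (0.08 log units; that floor lies within the scatter) lay within the scatter, the step from compound 2 to compound 4 is expected to be about a 1.2-fold lower number from compound 2 to compound 4 (0.06 log units; within the scatter). Compound 4 is therefore estimated at 50000 nM, within a range from 25000 nM to 100000 nM.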

Compound 4, half-maximal cytotoxic concentration: > 100000 nM
Compound 4: no number, only a limit; the forecaster's own chance of this, stated with the estimate: 15%; middle value at least 2.0-fold (0.30 log units) from the limit.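

In this assay compound 4 gives > 100000 nM, which is a limit of the test and not a number. Placing a nitro group on compound 2 gives an at least 1.7-fold higher number from compound 2 to compound 4 (0.23 log units; that floor lies within the scatter), so even this smallest possible size of the step does not show a real change, and a true value further up cannot be ruled out; set beside the same change on the other core, the comparison stays unsettled: the same change on two cores in this assay, an at least 1.2-fold lower number (0.08 log units; that floor lies within the scatter) from compound 1 to compound 3 and an at least 1.7-fold higher number (0.23 log units; that floor lies within the scatter) from compound 2 to compound 4; the limit leaves it open whether they differ The two cores therefore neither show that this change carries over from one to the other nor show that it behaves differently, and neither step has a measured size, as both rest on a limit: the limit of > 100000 nM in this assay, at which 2 of the 4 values shown sit.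

The compounds shown hold the nitro group at a single place on each core, so they leave open whether moving it on one core would alter the result in this test. They also leave open whether a nitrile or a carboxylic acid in place of the nitro group, or a longer chain in place of the chain of compound 2, would bring a value that can be read as a number.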